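Swapping the aryl ketone in a furan-bearing series

The compounds below may be only part of what the source reports. "The series", "measured", "known", "first", "only" and "open" are said of these compounds alone.

Of the compounds shown here, three sharing one core have been measured in a functional assay on PC-3 cells (Homo sapiens) for cytotoxicity, read by MTT assay, with a stated time of 48 h; on this read-out lower numbers stand for stronger inhibition and higher numbers for weaker inhibition. Compound 1 `COc1cc(C(=O)C2Sc3nnc(-c4cc(OC)c(OC)c(OC)c4)n3NC2c2ccco2)cc(OC)c1OC` gives 52200 nM, compound 2 `COc1cc(-c2nnc3n2NC(c2ccco2)C(C(=O)c2ccc(Br)cc2)S3)cc(OC)c1OC` gives 36400 nM, and compound 3 `COc1cc(-c2nnc3n2NC(c2ccco2)C(C(=O)c2cccs2)S3)cc(OC)c1OC` gives 46200 nM. Among these three numbers compound 3 stands second highest, separated from the others by a 1.1-fold lower number from compound 1 to compound 3 (0.05 log units; within the scatter) and by a 1.3-fold higher number from compound 2 to compound 3 (0.10 log units; within the scatter), both within the scatter. The step to compound 4 `COc1cc(-c2nnc3n2NC(c2ccco2)C(C(=O)c2ccc(Cl)cc2)S3)cc(OC)c1OC` changes only the aryl group on the carbonyl: 4-chlorophenyl in place of thiophen-2-yl on a carbonyl carbon. The step that bears most directly on it is the one in which a halogenated phenyl ring was exchanged for the thiophene, a 1.3-fold higher number from compound 2 to compound 3 (0.10 log units; within the scatter), while the exchange of the trimethoxyphenyl for either group, a 1.4-fold lower number from compound 1 to compound 2 (0.16 log units; within the scatter) and a 1.1-fold lower number from compound 1 to compound 3 (0.05 log units; within the scatter), likewise stayed within the scatter. The exchange in this assay is therefore expected to give no step beyond the scatter, a 1.2-fold lower number from compound 3 to compound 4 (0.06 log units; within the scatter). Compound 4 is expected to give about 40000 nM in this assay, within a range from 20000 nM to 80000 nM.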

Compound 4, half-maximal inhibitory concentration: 67800 nM
Beside the measured number, compound 4's estimate is 1.7-fold (0.23 log units) below it; the measured number falls inside the stated range.
By their numbers in this assay, from the lowest: compounds 2, 3, 1 and 4 (each within the scatter of the next).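

With 4-chlorophenyl as a fourth group on the carbonyl carbon, this assay still shows no step beyond the scatter (a 1.5-fold higher number from compound 3 to compound 4 (0.17 log units; within the scatter)), so the exchange of thiophen-2-yl for a chlorinated phenyl ring does not separate the two compounds. The closest change in the set, chloro in place of bromo on an aromatic carbon, gives the largest step seen so far (a 1.9-fold higher number from compound 2 to compound 4 (0.27 log units; within the scatter)) but also stays within the scatter, as does the exchange of the 3,4,5-trimethoxyphenyl group (a 1.3-fold higher number from compound 1 to compound 4 (0.11 log units; within the scatter)), so all four groups at this position remain indistinguishable in this read-out. Nothing available explains these small differences.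

From the compounds shown here alone, it remains open whether an amine or a carboxylic acid on the phenyl ring would give a step beyond the scatter. The same question stands for a longer chain in place of the aryl group on the carbonyl carbon.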